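Cytotoxicity After Octylsulfanyl Replaces Ethoxy

This account rests on a few compounds, and the source may have more. Where it says the series, first, only, none or still open, it means among the compounds named here.

Three compounds share one core and differ only in the group on the aromatic carbon: compound 1 `Nc1nc(OCC(F)(F)F)c2ncn(/C=C3/CC3(CO)CO)c2n1`, compound 2 `C=CCOc1nc(N)nc2c1ncn2/C=C1/CC1(CO)CO` and compound 3 `CCOc1nc(N)nc2c1ncn2/C=C1/CC1(CO)CO`. In an ADME assay on HFF cells (Homo sapiens) for cytotoxicity, with a stated time of 8 days (a higher number here means that more compound is tolerated, a lower number that less compound is tolerated), compound 1 gives > 300000 nM, which is a limit of the assay and not a number. In this assay compound 2 gives > 300000 nM, again a limit. In this assay compound 3 gives > 300000 nM, also a limit. Compound 3 therefore stands at the limit of > 300000 nM in this assay, at which 3 of the 3 values shown sit, together with every other value shown. The steps among these compounds, a step that the two limits leave unreadable from compound 1 to compound 2, a step that the two limits leave unreadable from compound 1 to compound 3 and a step that the two limits leave unreadable from compound 2 to compound 3, cannot be read.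

Compound 4 `CCCCCCCCSc1nc(N)nc2c1ncn2/C=C1/CC1(CO)CO` follows from compound 3 by a larger exchange: octylsulfanyl in place of ethoxy on an aromatic carbon. Within the data shown here, no measured step covers an exchange of this kind, so no direction can be taken from the data. The step of an at least 1.5-fold lower number from compound 3 to compound 4 (0.17 log units; that floor lies within the scatter) is expected to stay small, since every neighbour sits at the limit. Compound 4 is therefore expected near 200000 nM, within 30000 nM to 300000 nM.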

Compound 4, half-maximal cytotoxic concentration: > 300000 nM
Compound 4: no number, only a limit; the forecaster's own chance of this, stated with the estimate: 50%; middle value at least 1.5-fold (0.17 log units) from the limit.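

In this assay compound 4 gives > 300000 nM, a limit of the assay and not a number. The steps from compounds 1, 2 and 3 to compound 4 cannot be read, because all four compounds share one limit: the limit of > 300000 nM in this assay, at which 4 of the 4 values shown sit.

The compounds shown leave open whether octylsulfanyl in place of ethoxy changes the tolerated concentration at all.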